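Benzyl capping of the aryl hydroxy in the series

The source may report more compounds than this note shows. Statements on the series, on what has been measured and on what is new or still open speak of the compounds shown alone.

Measured in a functional assay on MCF7 cells (Homo sapiens) for inhibition, read by MTT assay, with a stated time of 72 h (a lower number here means a stronger inhibitor, a higher number a weaker inhibitor), so far
compound 1 `COC(=O)C1=C(N)Oc2cc(O)ccc2C1c1ccccc1` gives 10800 nM
compound 2 `COC(=O)C1=C(N)Oc2cc(O)ccc2C1c1ccc(O)cc1` gives > 100000 nM as a limit
compound 3 `CCOC(=O)C1=C(N)Oc2cc(O)ccc2C1c1ccc(O)cc1` gives > 100000 nM as a limit

Compound 3 stands only at the limit > 100000 nM and has no number. Compound 4 `CCOC(=O)C1=C(N)Oc2cc(O)ccc2C1c1ccc(OCc2ccccc2)cc1` carries benzyl in place of hydrogen on an oxygen on an aromatic ring, hydroxy to benzyloxy. The readable guide is an at least 9.2-fold higher number from compound 1 to compound 2 (0.96 log units; beyond the scatter), where the hydroxy entered, while a step that the two limits leave unreadable from compound 2 to compound 3 adds nothing. Masking that hydroxy should therefore move the number back toward compound 1 at 10800 nM, though benzyl itself is untested. The expected change is an at least 4.0-fold lower number from compound 3 to compound 4 (0.60 log units; beyond the scatter), a lower number in this assay by estimate. Compound 4 is estimated at 25000 nM, with an expected range of 5000 nM to 100000 nM for now.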

Compound 4, half-maximal inhibitory concentration: 4500 nM
The estimate for compound 4 lay 5.6-fold (0.74 log units) above the measured number; the measured number lies below the stated range.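

Capping this hydroxy with benzyl gives, in this assay, an at least 22-fold lower number from compound 3 to compound 4 (1.34 log units; beyond the scatter), the first readable value for a compound with an ethyl ester. The oxygen on the aromatic ring therefore accepts a benzyl group, and the number is measurable again once its hydrogen is replaced. Compound 3 stands at a limit and has no number, so the true size of this step stays unknown: the limit of > 100000 nM in this assay, at which 2 of the 4 values shown sit.

On these data alone, whether the gain comes from the added aromatic ring or only from the lost hydroxy hydrogen stays open. Methoxy or a longer chain on this oxygen would separate the two.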